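Changing the Ring Nitrogen Substituent: Benzyl to Methylsulfonyl

This account rests on a few compounds, and the source may have more. Where it says the series, first, only, none or still open, it means among the compounds named here.

Measured so far:
compound 1, `COc1cc(C(F)(F)F)cc(C(F)(F)F)c1C(=O)NC1(c2ccccc2)CCCN(CC2CC2)C1`: 380 nM
compound 2, `COc1cc(C(F)(F)F)cc(C(F)(F)F)c1C(=O)NC1(c2ccccc2)CCCN(Cc2ccccc2)C1`: 6700 nM

Both compounds were tested in an assay on cells for inhibition of sodium- and chloride-dependent glycine transporter 1 (Homo sapiens) (on this read-out higher numbers stand for an effect only at larger amounts of compound and lower numbers for an effect already at smaller amounts), where compound 1 gives 380 nM and compound 2 gives 6700 nM. Among the compounds with values here, compound 2 therefore stands at the higher of the two numbers, and the only step so far, an 18-fold higher number from compound 1 to compound 2 (1.25 log units; beyond the scatter), shows that what sits on the chain carbon attached to the ring nitrogen matters a great deal in this assay.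

Compound 3, `COc1cc(C(F)(F)F)cc(C(F)(F)F)c1C(=O)NC1(c2ccccc2)CCCN(S(C)(=O)=O)C1`, has not yet been measured. Its difference from compound 2 is methylsulfonyl in place of benzyl on an amine nitrogen in a ring. Within the data shown here, the step from compound 1 to compound 2 bears on this only indirectly: it tells that the group on the ring nitrogen moves the number strongly, but no measured compound carries a methylsulfonyl, so the direction cannot be read from the data. A sizeable step in either direction is plausible, and the estimate stays close to compound 2 with a wide range. For compound 3 the expected value in this assay is 3000 nM, between 500 nM and 18000 nM, which corresponds to an expected step of a 2.2-fold lower number from compound 2 to compound 3 (0.35 log units; beyond the scatter).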

Compound 3, half-maximal effective concentration: > 10000 nM
Compound 3 was reported as a limit (the forecaster's own chance of this, stated with the estimate: 10%); at least 3.3-fold (0.52 log units) between middle value and limit.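

In this assay compound 3 is reported only as a limit, not as a number: the limit of > 10000 nM in this assay, at which 1 of the 3 values shown sits. As far as these compounds go, the comparison with the benzyl compound therefore gives only a floor, an at least 1.4-fold higher number from compound 2 to compound 3 (0.17 log units; that floor lies within the scatter), so this result alone does not separate the two compounds, and the true size of the step remains unknown. The comparison with the cyclopropylmethyl compound is much clearer, an at least 26-fold higher number from compound 1 to compound 3 (1.42 log units; beyond the scatter), which shows that a methylsulfonyl group on the amine nitrogen in the ring, with its two hydrogen-bond acceptors and no ring, does not retain the much lower number seen with cyclopropylmethyl at this position.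

The three compounds cannot show whether the loss follows from the sulfonyl group itself or simply from the absence of a cyclopropylmethyl group, and an acetyl group or a plain methyl on the same nitrogen would help to tell these apart. From the compounds shown here alone, it also remains open whether other small groups on the chain carbon, such as cyclobutyl or isopropyl, would give numbers near or below that of compound 1, whose value is 380 nM.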